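The compounds below may be only part of what the source reports. "The series", "measured", "known", "first", "only" and "open" are said of these compounds alone.

Compound 1, `CCCS(=O)(=O)Nc1cccc2c1CCC2c1ncc[nH]1`, in a functional assay on CHO cells for agonist activity at Alpha-1A adrenergic receptor (Homo sapiens), read by FLIPR and calcium flux; a higher number here means that more compound is needed for the effect, a lower number that less compound is needed: 1340 nM.
Compound 2, `CCS(=O)(=O)Nc1cccc2c1CCC2c1ncc[nH]1`, in this assay: 32 nM.

Among the compounds with values here, compound 2 stands at the lower of the two numbers; the single measured step, a 42-fold lower number from compound 1 to compound 2 (1.62 log units; beyond the scatter), is large. Compound 3, `c1cc(-c2cn[nH]c2)c2c(c1)C(c1ncc[nH]1)CC2`, differs from compound 2 by 1H-pyrazol-4-yl in place of (ethylsulfonyl)amino on an aromatic carbon. Within the data shown here, no measured step involves an exchange of this kind; the one step known concerns chain length only and does not bear on it, so the expectation rests on the size of the change alone. The number for compound 3 is expected to rise from that of compound 2, with wide uncertainty. For compound 3 the estimate is 300 nM, ranging from 30 nM to 3000 nM. The expected step is a 9.4-fold higher number from compound 2 to compound 3 (0.97 log units; beyond the scatter).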

Compound 3, half-maximal effective concentration: 14 nM
Compound 3: the middle estimate sits 21-fold (1.33 log units) above what was measured; the measured number lies below the stated range.
By their numbers in this assay, from the lowest: compound 3; then compound 2; then compound 1.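

In this assay, the aromatic carbon holding (ethylsulfonyl)amino also accepts 1H-pyrazol-4-yl, a ring with no sulfonyl group, and the number falls (a 2.3-fold lower number from compound 2 to compound 3 (0.36 log units; beyond the scatter)). The exchange from (propylsulfonyl)amino gives a larger step (a 96-fold lower number from compound 1 to compound 3 (1.98 log units; beyond the scatter)), so at this carbon a low number does not depend on a sulfonyl group among these compounds. No measurement available here accounts for either step. Still open, from the compounds shown here alone, is whether an amine, a carboxylic acid or another five-membered aromatic ring at this carbon would keep the number this low. A methyl on the pyrazole nitrogen is equally untested in the compounds shown.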